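Difluoronitrophenyl placement on the amine nitrogen

The compounds below may be only part of what the source reports. "The series", "measured", "known", "first", "only" and "open" are said of these compounds alone.

Compound 1 `Nc1nc(N)c(CCCN(Cc2ccc(NC(CCC(=O)O)C(=O)O)cc2)c2cc(F)c(F)cc2[N+](=O)[O-])c(O)n1`; in a functional assay on CCRF-CEM cells (Homo sapiens) for cytotoxicity, in the absence of a further agent (a lower number here means a stronger inhibitor, a higher number a weaker inhibitor), compound 1 gives > 100000 nM.
Compound 2 `Nc1nc(N)c(CCCNc2cc(F)c(F)cc2[N+](=O)[O-])c(O)n1`; in this assay compound 2 gives 97000 nM.
Compound 3 `CC(C)(C)OC(=O)CCC(Nc1ccc(CN(CCCc2c(N)nc(N)nc2O)c2cc(F)cc(F)c2[N+](=O)[O-])cc1)C(=O)OC(C)(C)C`; in this assay compound 3 gives 2400 nM.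

For compound 1 the value shown is a limit of the assay and not a number (the limit of > 100000 nM in this assay, at which 1 of the 3 values shown sits). Of the two numbers that do exist, compound 3 stands lowest; compound 2 is the nearest, and the gap between them lies beyond the scatter.

Compound 4 `CC(C)(C)OC(=O)CCC(Nc1ccc(CN(CCCc2c(N)nc(N)nc2O)c2ccc([N+](=O)[O-])c(F)c2F)cc1)C(=O)OC(C)(C)C` has not yet been measured in this assay. It differs from compound 3 in one place:
2,3-difluoro-4-nitrophenyl in place of 3,5-difluoro-2-nitrophenyl on an amine nitrogen
The two have the same atoms, joined differently. Within the data shown here, no measured pair shows a change of this kind, so the size of the step has no precedent here. The step from compound 3 to compound 4 is expected to be small, a 1.3-fold higher number from compound 3 to compound 4 (0.10 log units; within the scatter), with no direction favoured beyond the scatter. Compound 4 is therefore expected near 3000 nM in this assay, within 800 nM to 12000 nM.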

Compound 4, half-maximal inhibitory concentration: 20000 nM
Compound 4: the middle estimate sits 6.7-fold (0.82 log units) below what was measured, outside the stated range (above it).
By their numbers in this assay, from the lowest: compound 3; then compound 4; then compound 2. At a limit, above all of these: compound 1.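

On the amine nitrogen whose other neighbours are saturated chain carbons, replacing 3,5-difluoro-2-nitrophenyl with 2,3-difluoro-4-nitrophenyl gives an 8.3-fold higher number from compound 3 to compound 4 (0.92 log units; beyond the scatter) in this assay. The two groups have the same atoms and the same counts of hydrogen-bond donors and acceptors, so in this pair the way the aryl group is joined, and not its composition, goes with the change in value. Nothing measured here accounts for the step.

On these data alone, it remains open whether the same step appears when free carboxylic acids replace the tert-butyl esters. A nitrile in place of the nitro group, or a longer chain from the core to the amine nitrogen, would show whether the value at this position depends on those parts too.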